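The source may report more compounds than this note shows. Statements on the series, on what has been measured and on what is new or still open speak of the compounds shown alone.

Measured so far in a functional assay on P388 cells (Mus musculus) for antiproliferative activity, read by colorimetric assay and MTT assay; on this read-out lower numbers stand for stronger inhibition and higher numbers for weaker inhibition:
compound 1, `O=S(=O)(Nc1cccc2cc[nH]c12)c1ccc(Cl)cc1`, gives 6 ug/mL;
compound 2, `O=S(=O)(Nc1ccc(Cl)c2cc[nH]c12)c1ccc(Cl)cc1`, gives 4.6 ug/mL;
compound 3, `O=[N+]([O-])c1ccc(S(=O)(=O)Nc2cccc3cc[nH]c23)cc1`, gives 8.2 ug/mL.

From compound 1 to compound 2 the change is chloro in place of hydrogen on an aromatic carbon, and the step it made was a 1.3-fold lower number from compound 1 to compound 2 (0.12 log units; within the scatter). Compound 4, `O=[N+]([O-])c1ccc(S(=O)(=O)Nc2cccc3cc(Cl)[nH]c23)cc1`, carries the same kind of change relative to compound 3: chloro in place of hydrogen on an aromatic carbon. The cores of compound 1 and compound 3 differ by nitro in place of chloro on an aromatic carbon. The place is not the same: in compound 2 the chloro sits on a six-membered aromatic ring of carbon only, para to a large group, whereas in compound 4 it sits on a five-membered aromatic ring with 1 nitrogen, next to the ring nitrogen. Resting on the step from compound 1 to compound 2, a 1.3-fold lower number from compound 1 to compound 2 (0.12 log units; within the scatter), the expected step in this assay is a 1.3-fold lower number from compound 3 to compound 4 (0.10 log units; within the scatter). Compound 4 is thus estimated at 6.5 ug/mL, spanning 3 ug/mL to 14 ug/mL.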

Compound 4, half-maximal inhibitory concentration: 21 ug/mL
Compound 4: the middle estimate sits 3.2-fold (0.51 log units) below what was measured; the measured number lies above the stated range.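

In this assay the chloro change gave a 2.6-fold higher number from compound 3 to compound 4 (0.41 log units; beyond the scatter), and it did not carry over unchanged from the earlier core: the same change on two cores in this assay, a 1.3-fold lower number (0.12 log units; within the scatter) from compound 1 to compound 2 and a 2.6-fold higher number (0.41 log units; beyond the scatter) from compound 3 to compound 4, 3.3-fold (0.52 log units) apart, beyond the scatter of two such steps

The two steps differ in more than the core, however, since the chloro sits on a six-membered aromatic ring of carbon only in compound 2 but on a five-membered aromatic ring with 1 nitrogen, next to the ring nitrogen, in compound 4. This one pair of steps therefore does not show whether the core or the place lies behind the gap, and it sets no rule for the series.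

Open, going by these compounds, is how chloro behaves at the same place on both cores, which would separate these two differences. Also open, on these data alone, is how a methyl group or an amine would behave next to the ring nitrogen.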